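Urea to benzothiazolylamine on the shared core

The source may report more compounds than this note shows. Statements on the series, on what has been measured and on what is new or still open speak of the compounds shown alone.

Compound 3 `Cc1ccc(-c2c(C)nc(NC(=O)Nc3ccccc3)c(C)c2C(OC(C)(C)C)C(=O)O)cc1C` holds the second highest number of the three measured in an ADME assay on MT4 cells (Homo sapiens) for cytotoxicity, read by MTT assay (on this read-out higher numbers stand for lower toxicity in this test and lower numbers for higher toxicity in this test), at 9900 nM. Its nearest neighbour is compound 2 `Cc1ccc(-c2c(C)nc(NC(=O)NC3CCCCCC3)c(C)c2C(OC(C)(C)C)C(=O)O)cc1C`, which gives 7700 nM; the gap a 1.3-fold higher number from compound 2 to compound 3 (0.11 log units; within the scatter) lies within the scatter. The furthest is compound 1 `Cc1ccc(-c2c(C)nc(NC(=O)NC3CCOCC3)c(C)c2C(OC(C)(C)C)C(=O)O)cc1C`, which gives 29000 nM; the step of a 2.9-fold lower number from compound 1 to compound 3 (0.47 log units; beyond the scatter) is beyond the scatter, as is a 3.8-fold lower number from compound 1 to compound 2 (0.58 log units; beyond the scatter).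

Compound 4 `Cc1ccc(-c2c(C)nc(Nc3nc4ccccc4s3)c(C)c2C(OC(C)(C)C)C(=O)O)cc1C` differs from compound 3 by 1,3-benzothiazol-2-yl in place of phenylcarbamoyl on a nitrogen on an aromatic ring. Among the measured compounds shown here, all three measured steps vary the group on the amide-type nitrogen while keeping the urea; none removes the urea itself, so no step matches this change. Those steps were at most modest, and the two bearing on a ring-for-ring swap at this position, the steps from compound 1 to compound 2 and from compound 1 to compound 3, moved the number downward only modestly. A step no larger than that, in either direction, is expected, with the estimated step of a 1.2-fold lower number from compound 3 to compound 4 (0.09 log units; within the scatter). For compound 4 the estimate in this assay is 8000 nM, within 3000 nM to 25000 nM.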

Compound 4, half-maximal cytotoxic concentration: 6600 nM
Beside the measured number, compound 4's estimate is 1.2-fold (0.08 log units) above it, and the stated range covers the measured number.
By their numbers in this assay, from the lowest: compounds 4, 2 and 3 (each within the scatter of the next); then compound 1.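

In this assay, 1,3-benzothiazol-2-yl can stand in place of the carbamoyl groups of the aryl and cycloheptyl ureas with no change beyond the scatter: a 1.5-fold lower number from compound 3 to compound 4 (0.18 log units; within the scatter), and a 1.2-fold lower number from compound 2 to compound 4 (0.07 log units; within the scatter). Among the compounds shown here, the urea itself is therefore not required for a number in the range of compound 2 and compound 3, which the earlier steps, all keeping the urea, could not show. For the compounds shown here, compound 1 remains apart from the other three, with a 4.4-fold lower number from compound 1 to compound 4 (0.64 log units; beyond the scatter), so the oxan-4-yl urea is still the only group here that separates from the rest. Nothing measured here explains these numbers.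

Open, on these data alone, is how a benzothiazole carrying a morpholine or a carboxylic acid would read in this test. Also open, as far as these compounds go, is how an acetyl group on that nitrogen, a plain amide in place of the urea, would read.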